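The compounds below may be only part of what the source reports. "The series", "measured", "known", "first", "only" and "open" are said of these compounds alone.

Measured in a functional assay on A549 cells (Homo sapiens) for inhibition, read by sulforhodamine B assay, with a stated time of 48 h (on this read-out lower numbers stand for stronger inhibition of growth and higher numbers for weaker inhibition of growth), so far:
- compound 1 `CCN(C(=O)c1cc(C(C)C)c(O)cc1O)c1ccc(NC(=O)CCCCCCC(=O)NO)cc1` gives 5630 nM
- compound 2 `CC(C)c1cc(C(=O)Nc2ccc(NC(=O)CCCCCCC(=O)NO)cc2)c(O)cc1O` gives > 10000 nM
- compound 3 `CC(C)c1cc(C(=O)N(C)c2ccc(NC(=O)CCCCCCCC(=O)NO)cc2)c(O)cc1O` gives 440 nM

Compound 2 stands at the limit of > 10000 nM in this assay, at which 1 of the 3 values shown sits, and has no number of its own. Compound 4 `CC(C)c1cc(C(=O)N(c2ccc(NC(=O)CCCCCCC(=O)NO)cc2)C(C)C)c(O)cc1O` carries isopropyl in place of hydrogen on an amide-type nitrogen, that is, isopropyl in place of hydrogen on an amide-type nitrogen. Going by the values given here, the one measured step on this nitrogen is an at least 1.7-fold higher number from compound 1 to compound 2 (0.24 log units; that floor lies within the scatter), with hydrogen in place of ethyl, so it gives only a floor. Among the compounds with values here, compound 2 has no clean partner in the other compound either: differing from it in more than one place, compound 3 with 440 nM gives no clean step on this nitrogen. With ethyl on that nitrogen, compound 1 reads 5630 nM, so compound 4 is expected near that number, and a modest step toward stronger inhibition is expected in this assay, though it may not clear the scatter. The estimated step is an at least 2.0-fold lower number from compound 2 to compound 4 (0.30 log units; that floor lies within the scatter). The estimate for compound 4 is 5000 nM, with an expected range from 1800 nM to 14000 nM.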

Compound 4, concentration for 50% growth inhibition: > 10000 nM
Compound 4 ended at the assay's limit (the forecaster's own chance of this, stated with the estimate: 25%); middle value at least 2.0-fold (0.30 log units) away from the limit.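

On the amide-type nitrogen, isopropyl does not separate from hydrogen in this assay, and the step between compound 2 and compound 4 cannot be read because both values are limits of the assay: the limit of > 10000 nM in this assay, at which 2 of the 4 values shown sit.

Going from ethyl to isopropyl on this nitrogen gives an at least 1.7-fold higher number from compound 1 to compound 4 (0.24 log units; that floor lies within the scatter), so no order between these two groups can be claimed. Among compounds 1, 2 and 4, only compound 1 has a number of its own, 5630 nM.

On these data alone, how a benzyl or a 2-methoxyethyl group on this nitrogen would read remains open. Compound 3 differs from the others in more than one place, so its 440 nM leaves the effect of methyl on this nitrogen open as well.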